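A few compounds are considered here, and "the series" means these few. Any claim that something is new, unique, unknown or untested is made for them only; others in the source may bear on it.

Measured so far:
- Compound 1, `CC1(C)[C@H]2CC[C@]1(C)N(Cc1cn(-c3cccc(F)c3)nn1)C(=O)C2`: 530 nM
- Compound 2, `CC1(C)[C@H]2CC[C@]1(C)N(Cc1cn(-c3ccccc3Br)nn1)C(=O)C2`: 500 nM
- Compound 3, `CC1(C)[C@H]2CC[C@]1(C)N(Cc1cn(-c3ccc(F)cc3)nn1)C(=O)C2`: 500 nM

All three share one core, and differ only in the aromatic group carried on an aromatic nitrogen. In a functional assay on SGC-7901 cells (Homo sapiens) for inhibition, read by MTT assay, with a stated time of 24 h (a lower number here means a stronger inhibitor, a higher number a weaker inhibitor), compound 1 gives 530 nM, compound 2 gives 500 nM and compound 3 gives 500 nM. Compound 3 stands level with compound 2 at the digits printed, and the two together hold the lowest numbers of the three, but every gap here is small: a 1.1-fold lower number from compound 1 to compound 3 (0.03 log units; within the scatter) and no change at the digits printed from compound 2 to compound 3 (within the scatter).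

Compound 4, `CC1(C)[C@H]2CC[C@]1(C)N(Cc1cn(-c3ccccc3O)nn1)C(=O)C2`, is not yet measured. It differs from compound 3 in one place: 2-hydroxyphenyl in place of 4-fluorophenyl on an aromatic nitrogen.

The measured steps that bear on this are changes of the same aromatic group on the same nitrogen. a 1.1-fold lower number from compound 1 to compound 2 (0.03 log units; within the scatter) swapped both the halogen and its position; a 1.1-fold lower number from compound 1 to compound 3 (0.03 log units; within the scatter) moved the fluorine; no change at the digits printed from compound 2 to compound 3 (within the scatter) exchanged bromine for fluorine at a different position. None moved the number beyond the scatter. For the measured compounds named here, no measured step introduces a hydroxyl, so the data give no direct guide for a group with a hydrogen-bond donor and acceptor. On what is shown, a step of about no change at the digits printed from compound 3 to compound 4 (within the scatter) is expected for compound 4, with no clear direction. Compound 4 is therefore estimated at 500 nM, in the range 250 nM to 1000 nM.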

Compound 4, half-maximal inhibitory concentration: 410 nM
Compound 4: the middle estimate sits 1.2-fold (0.09 log units) above what was measured; the measured number falls inside the stated range.
By their numbers in this assay, from the lowest: compounds 4, 2, 3 and 1 (each within the scatter of the next).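

Of the four compounds, only compound 4 has a group with a hydrogen-bond donor and acceptor on this nitrogen, yet in this assay its number stays close to the others: the steps are a 1.2-fold lower number from compound 3 to compound 4 (0.09 log units; within the scatter) and a 1.2-fold lower number from compound 2 to compound 4 (0.09 log units; within the scatter) and a 1.3-fold lower number from compound 1 to compound 4 (0.11 log units; within the scatter) with no step beyond the scatter. The second of these is the narrowest comparison, since only hydroxy replaces bromo on an aromatic carbon, and it shows that a hydroxy group and a halogen on the phenyl ring give numbers that cannot be told apart here. Nothing available explains why the number holds so steady across these groups.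

An amine or a carboxylic acid on the phenyl ring, or a longer chain in its place, could still move the number beyond the scatter. Going by these compounds, whether any of these would do so, and in which direction, remains open.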